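Chain acid to tetrazole on the acetophenone core

The compounds below may be only part of what the source reports. "The series", "measured", "known", "first", "only" and "open" are said of these compounds alone.

Measured so far in a functional assay on ileum (Cavia porcellus) for inhibition of cysteinyl leukotriene receptor (Homo sapiens); on this read-out lower numbers stand for lower potency and higher numbers for higher potency (the scale is a negative logarithm):
compound 1 `CCCc1c(OCCCCCCCCC(=O)O)ccc(C(C)=O)c1O` gives 5.8;
compound 2 `CCCc1c(OCCCCC(=O)O)ccc(C(C)=O)c1O` gives 5.8.

Compound 2 stands level with compound 1 on the numbers shown: the one measured step, no change at the digits printed from compound 1 to compound 2 (within the scatter), is within the scatter, so shortening the acid-bearing chain from the aryl oxygen changes nothing that can be read here.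

Compound 3 `CCCc1c(OCCCCCCc2nn[nH]n2)ccc(C(C)=O)c1O` is not yet measured. It differs from compound 2 in one place: 2-(2H-tetrazol-5-yl)ethyl in place of carboxy on a saturated chain carbon, four bonds along the chain from an oxygen on an aromatic ring. The chain from the aryl oxygen grows by the count given there and the acid is exchanged for the five-membered aromatic ring with four hetero atoms, carrying the same number of hydrogen-bond donors but more acceptors.

Among the measured compounds shown here, only the step from compound 1 to compound 2 bears on this, and it bears only on the length of the chain, where it showed no change. For the measured compounds named here, no measured step covers the exchange of carboxy for the tetrazolyl ring, so the direction of that part is open. Compound 3 is therefore expected near compound 2, with a wide range: 6, from 5.3 to 6.8, which is an expected step of a number 0.20 log units higher from compound 2 to compound 3 (within the scatter) in this assay.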

Compound 3, negative logarithm of the antagonist equilibrium constant: 7.1
The estimate for compound 3 lay 1.10 log units below the measured number; measured number outside the range, above it.
By their numbers in this assay, from the lowest: compounds 1 and 2 (each within the scatter of the next); then compound 3.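

In this assay, among the compounds shown here, the exchange of carboxy for 2-(2H-tetrazol-5-yl)ethyl on a saturated chain carbon, four bonds along the chain from an oxygen on an aromatic ring, gives a number 1.30 log units higher from compound 2 to compound 3 (beyond the scatter) and is the first change to pass the scatter, whereas the step between the two acids, no change at the digits printed from compound 1 to compound 2 (within the scatter), moved nothing that can be read. The comparison with the longer acid points the same way, since 2H-tetrazol-5-yl in place of 2-carboxyethyl gives a number 1.30 log units higher from compound 1 to compound 3 (beyond the scatter) and the tetrazolyl compound therefore stands clear of both acids, so this position, indifferent to the chain difference between compound 1 and compound 2, does respond when the chain end is changed. Nothing available here accounts for the rise.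

Both steps change the chain together with its end group, so the share of the tetrazolyl ring alone remains unsettled, and a carboxylic acid on a chain of the length carried by compound 3 would separate the two. Equally open, from the compounds shown here alone, is whether the 2H-tetrazol-5-yl ring keeps this level on a shorter chain such as that of compound 2 or on a longer chain such as that of compound 1.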